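This account rests on a few compounds, and the source may have more. Where it says the series, first, only, none or still open, it means among the compounds named here.

Compound 1, `CC(C)N1CCc2nc(C#Cc3cccs3)ccc2C1=O`, in an assay on HEK293 cells for displacement of a labelled ligand from metabotropic glutamate receptor 5 (Homo sapiens), with a stated time of 2 h; on this read-out lower numbers stand for stronger inhibition and higher numbers for weaker inhibition: 1930 nM.
Compound 2, `O=C1c2ccc(C#Cc3cccc(Cl)c3)nc2CCN1C1CCCC1`, in this assay: 5230 nM.

Of the two measured compounds, compound 2 gives the higher number; compound 1 sits at a lower number, and the gap between them lies beyond the usual scatter. Compound 3, `O=C1c2ccc(C#Cc3cccs3)nc2CCN1C1CCCC1`, has not been measured in this assay. It differs from compound 2 in one place: thiophen-2-yl in place of 3-chlorophenyl on a triple-bonded carbon. The same thiophen-2-yl group sits on the triple-bonded carbon of compound 1, which in this assay gives 1930 nM, though compound 1 also carries a different group on the amide nitrogen, so its value is not a clean test of this single change. The step from compound 2 to compound 3 in this assay is expected to run toward a lower number, at a size near the edge of the scatter: a 2.1-fold lower number from compound 2 to compound 3 (0.32 log units; beyond the scatter). Compound 3 is estimated at 2500 nM, with a range from 900 nM to 7000 nM.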

Compound 3, inhibition constant: 2840 nM
For compound 3 the middle estimate is 1.1-fold (0.06 log units) below the measured one; the measured number falls inside the stated range.
By their numbers in this assay, from the lowest: compounds 1, 3 and 2 (each within the scatter of the next, the first and the last beyond it).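

In this assay, thiophen-2-yl in place of 3-chlorophenyl on a triple-bonded carbon gives a 1.8-fold lower number from compound 2 to compound 3 (0.27 log units; within the scatter) with cyclopentyl held on the amide-type nitrogen, so this swap of aromatic groups does not separate the two compounds. With thiophen-2-yl held, cyclopentyl in place of isopropyl on that nitrogen gives a 1.5-fold higher number from compound 1 to compound 3 (0.17 log units; within the scatter) and likewise separates nothing. Compound 1 and compound 2 differ in two places, so only these single steps show that neither change on its own goes beyond the scatter.

The compounds shown leave open how a furan-2-yl or pyridin-2-yl group would read on the triple-bonded carbon, and how a methyl group or a longer chain would read on the amide-type nitrogen. They also leave open whether any single change at either place can go beyond the scatter. Nothing available offers an explanation for these values.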